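Oxygen to Nitrogen Linker on a Nitrile-Bearing Core

This account rests on a few compounds, and the source may have more. Where it says the series, first, only, none or still open, it means among the compounds named here.

The account follows three measured compounds and one that is not yet measured. Compound 1 `N#Cc1c(-c2ccc(OC3CCOCC3)c(Cl)c2)ccn2c(CC(F)(F)F)cnc12` carries a nitrile on the shared core and an (oxan-4-yl)oxy group on the outer ring. In a functional assay on CHO cells for agonist activity at metabotropic glutamate receptor 2 (Homo sapiens) (a higher number here means a larger maximal response, a lower number a smaller maximal response), compound 1 gives 173%, the lowest of the three numbers seen. Compound 2 `FC(F)(F)Cc1cnc2c(Cl)c(-c3cc(Cl)c4[nH]ccc4c3)ccn12` gives 217% in this assay, a number beyond the scatter above that of compound 1. Among the compounds with values here, compound 3 `O[C@H]1CC[C@H](Nc2ccc(-c3ccn4c(CC(F)(F)F)cnc4c3Cl)cc2Cl)CC1` gives 293% in this assay, the highest of the three and again beyond the scatter above compound 1; it differs from compound 1 in more than one place, so no single step connects them.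

Compound 4 `N#Cc1c(-c2ccc(NC3CCOCC3)c(Cl)c2)ccn2c(CC(F)(F)F)cnc12` differs from compound 1 in one place: (oxan-4-yl)amino in place of (oxan-4-yl)oxy on an aromatic carbon. Within the data shown here, no measured pair shows this change in isolation. Among the measured compounds shown here, compound 3 is the only measured compound with a nitrogen-linked group on the outer ring, and it carries a different core, so it offers a hint rather than a step.

A modest rise is expected, with the step from compound 1 to compound 4 estimated at a number 32 percentage points higher from compound 1 to compound 4 (beyond the scatter). For compound 4 in this assay a largest response of 205% is estimated, within a range from 140% to 285%.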

Compound 4, largest response reached (Emax), in percent of the reference or control that the assay uses: 307%
The estimate for compound 4 lay 102 percentage points below the measured number; the whole stated range lies below it.
By their numbers in this assay, from the lowest: compound 1; then compound 2; then compound 3; then compound 4.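

In this assay, within the data shown here, (oxan-4-yl)amino in place of (oxan-4-yl)oxy gives a number 134 percentage points higher from compound 1 to compound 4 (beyond the scatter), and this is the only step that changes a single place. The two groups share the same count of 7 heavy atoms and the same six-membered non-aromatic ring with 1 hetero atom, so the linking atom on the aromatic carbon, ortho to a chloro group, is the only thing that differs, with 1 hydrogen-bond donor entering where 0 hydrogen-bond donors leave. On the nitrile-bearing core, then, the largest response reached at this position is highly sensitive to that one atom. Compound 3 could only hint at this. Its core differs.

The compounds shown leave open whether the same exchange gives a step of this size on the core of compound 3, which also carries a different ring on its nitrogen link. They also leave open how a thioether sulfur, a methylene unit or a methylated amine nitrogen would fare as the linking atom in this place. No measurement at hand accounts for the size of the step.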